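A fluorinated sulfonamide weighed against its nitro parent

The source may report more compounds than this note shows. Statements on the series, on what has been measured and on what is new or still open speak of the compounds shown alone.

Of the compounds shown here, three have been measured in an assay on MDA-MB-231 cells for displacement of a labelled ligand from C-X-C chemokine receptor type 4 (Homo sapiens), read by fluorescence and microscopy, with stated times of 10 min and 30 min; on this read-out higher numbers stand for an effect only at larger amounts of compound and lower numbers for an effect already at smaller amounts. Compound 1 `Cc1ccccc1C(=O)NCc1ccc(CNS(=O)(=O)c2ccc([N+](=O)[O-])cc2)cc1` gives 100 nM, compound 2 `O=C(NCc1ccc(CNS(=O)(=O)c2ccccc2Cl)cc1)c1cccnc1` gives 100 nM, and compound 3 `Cc1ccccc1S(=O)(=O)NCc1ccc(CNC(=O)c2cccnc2)cc1` gives 1000 nM. Compound 1 thus stands level with compound 2, the pair together at the lowest number of the three, while compound 3 lies a clear step above them. Among the compounds with values here, the one measured step, a 10-fold higher number from compound 2 to compound 3 (1.00 log units; beyond the scatter), shows that a small change of an aromatic substituent can shift the read-out beyond the scatter. Compound 4 `Cc1ccccc1C(=O)NCc1ccc(CNS(=O)(=O)c2ccccc2F)cc1` differs from compound 1 by 2-fluorophenyl in place of 4-nitrophenyl on a sulfonyl sulfur. Within the data shown here, no measured step covers this change directly, but compound 2, which also carries a halogen on a 2-substituted phenyl at the sulfonyl sulfur, gives 100 nM. Compound 4 is therefore expected to give about 200 nM, between 50 nM and 1000 nM, a step of a 2.0-fold higher number from compound 1 to compound 4 (0.30 log units; within the scatter) that is estimated to stay within the scatter.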

Compound 4, effective concentration (reported as EC, without a stated level of effect): 1000 nM
The estimate for compound 4 lay 5.0-fold (0.70 log units) below the measured number, within the range that was stated.
By their numbers in this assay, from the lowest: compounds 1 and 2 (each within the scatter of the next); then compounds 3 and 4 (each within the scatter of the next).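

On a sulfonyl sulfur, 2-fluorophenyl in place of 4-nitrophenyl gives a 10-fold higher number from compound 1 to compound 4 (1.00 log units; beyond the scatter) in this assay. Within the data shown here, this is the first measured step on the core of compound 1, and it shows that exchanging the whole aryl group at this position, not only a substituent on it, moves the read-out beyond the scatter. Nothing given here accounts for the size of this step.

The nitro group and the place of the substituent change together in this step, so their shares cannot be separated. Going by these compounds, how 4-fluorophenyl, 2-nitrophenyl or an aminophenyl group would read at this sulfur remains open.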